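Adding a second chloro to a benzylated purine-like core

A few compounds are considered here, and "the series" means these few. Any claim that something is new, unique, unknown or untested is made for them only; others in the source may bear on it.

Compound 1 `ClCc1cccc(Cn2cnc3ncnc(Cl)c32)c1` is the less toxic of the two measured compounds: in a functional assay on OVCAR-3 cells (Homo sapiens) for cytotoxicity, read by sulforhodamine B assay, with a stated time of 48 h (on this read-out lower numbers stand for higher toxicity in this test and higher numbers for lower toxicity in this test), compound 1 gives 43700 nM, whereas compound 2 `ClCc1cccc(Cn2cnc3c(Cl)nc(Cl)nc32)c1` gives 6450 nM, a gap beyond the usual scatter. Compound 3 `ClCc1cccc(Cn2cnc3nc(Cl)nc(Cl)c32)c1` differs from compound 1 by chloro in place of hydrogen on an aromatic carbon, placed between two ring nitrogen atoms of the shared core. Since compound 2, which also carries two chloro groups, reaches 6450 nM, the step from compound 1 to compound 3 is expected to be a clear move toward higher toxicity, a 5.5-fold lower number from compound 1 to compound 3 (0.74 log units; beyond the scatter). Compound 3 is therefore estimated at 8000 nM, within the range 3000 nM to 25000 nM.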

Compound 3, concentration lethal to 50% of the cells: 5370 nM
For compound 3 the middle estimate is 1.5-fold (0.17 log units) above the measured one; low and high end bracket the measured number.
By their numbers in this assay, from the lowest: compounds 3 and 2 (each within the scatter of the next); then compound 1.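

Chloro in place of hydrogen on an aromatic carbon, between two ring nitrogen atoms of the shared core, gives an 8.1-fold lower number from compound 1 to compound 3 (0.91 log units; beyond the scatter) in this assay. This single change shows that this position can affect the read-out, with one added chlorine atom moving the number toward higher toxicity in this test. Nothing at hand explains why the number moves.

From the compounds shown here alone, whether this shift is particular to chloro remains open. An amine or a methoxy group at this position would help show how much depends on the group itself.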